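Solubility of Three Quinolone Esters and an Untested Analogue

The source may report more compounds than this note shows. Statements on the series, on what has been measured and on what is new or still open speak of the compounds shown alone.

Measured compounds:
compound 1, `CCOC(=O)c1c(-c2ccccc2C)[nH]c2cc(OC)ccc2c1=O` — > 100000 nM
compound 2, `CCOC(=O)c1c(-c2cccc(OC)c2)[nH]c2cc(OC)ccc2c1=O` — > 100000 nM
compound 3, `CCOC(=O)c1c(-c2ccccc2C)[nH]c2cccc(OC)c2c1=O` — > 100000 nM

In a physicochemical assay for solubility, in phosphate buffer, at pH 7.4 (a lower number here means a less soluble compound, a higher number a more soluble compound), compound 1 gives > 100000 nM, which is a limit of the assay and not a number. In this assay compound 2 likewise gives > 100000 nM, again only a limit. Compound 3 reaches > 100000 nM, also a limit. Compound 3 and compound 1 share the same atoms joined differently; the difference between the two cores is not broken down here.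

The change from compound 1 to compound 2 is 3-methoxyphenyl in place of 2-methylphenyl on an aromatic carbon; its step, a step that the two limits leave unreadable from compound 1 to compound 2, cannot be read because of the limit of > 100000 nM in this assay, at which 3 of the 3 values shown sit. The same change applies from compound 3 to compound 4, `CCOC(=O)c1c(-c2cccc(OC)c2)[nH]c2cccc(OC)c2c1=O`: 3-methoxyphenyl in place of 2-methylphenyl on an aromatic carbon. The step that the limit leaves unreadable from compound 3 to compound 4 is expected to be small, resting on compound 3 sitting at > 100000 nM and on (the limit of > 100000 nM in this assay, at which 3 of the 3 values shown sit). Compound 4 is expected at 150000 nM, most likely reported again as a limit.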

Compound 4, solubility: > 100000 nM
Compound 4 ended at the assay's limit (the forecaster's own chance of this, stated with the estimate: 85%); the middle value lies beyond the limit too.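

No step can be read from compound 3 to compound 4, and none is added to the earlier unreadable one from compound 1 to compound 2: the limit of > 100000 nM in this assay, at which 4 of the 4 values shown sit.

The compounds shown leave open whether 3-methoxyphenyl in place of 2-methylphenyl changes anything in this assay.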